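A few compounds are considered here, and "the series" means these few. Any claim that something is new, unique, unknown or untested is made for them only; others in the source may bear on it.

Measured so far in a physicochemical assay for lipophilicity; on this read-out higher numbers stand for higher lipophilicity and lower numbers for lower lipophilicity:
compound 1 `CCC(=O)/C=C(C)/C=C/CC(C)CCCC(C)C`: 6.27; 6.68 (2 entries)
compound 2 `CCC(=O)/C=C(C)/C=C/CC(C)CCCC(C)(C)OC`: 5.07
compound 3 `CCSC(=O)/C=C(C)/C=C/CC(C)CCCC(C)(C)O`: 5.89

Compound 3 stands highest of the two single numbers in this assay; the nearest, compound 2, lies well below it, a gap beyond the scatter, while compound 1 has two entries rather than one number, as shown in the several entries of compound 1 in this assay, 6.27; 6.68 (2 entries). Compound 4 `CCC(=O)/C=C(C)/C=C/CC(C)CCCC(C)(C)O` has not yet been measured in this assay. It differs from compound 3 in one place: ethyl in place of ethylsulfanyl on a carbonyl carbon. Going by the values given here, no measured pair shows this exact change, so the size of the step is uncertain; a modest drop in this assay is expected. For compound 4 the estimated value in this assay is 5.2, with a range from 4.6 to 5.8, which means an expected step of a number 0.69 log units lower from compound 3 to compound 4 (beyond the scatter).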

Compound 4, partition coefficient: 4.18
Beside the measured number, compound 4's estimate is 1.02 log units above it; measured number outside the range, below it.
By their numbers in this assay, from the lowest: compound 4; then compound 2; then compound 3.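

In this assay, ethyl in place of ethylsulfanyl on a carbonyl carbon gives a number 1.71 log units lower from compound 3 to compound 4 (beyond the scatter) and so counts as a large step. Hydrogen in place of methyl on an oxygen on a saturated carbon gives a modest one, a number 0.89 log units lower from compound 2 to compound 4 (beyond the scatter) and thus both places move the number, the carbonyl carbon by more. Nothing at hand explains the size of either step. Still open, from the compounds shown here alone, is how an amine or a longer chain on that carbonyl carbon would read, and whether the ethylsulfanyl step keeps its size with methyl on that oxygen.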